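A few compounds are considered here, and "the series" means these few. Any claim that something is new, unique, unknown or untested is made for them only; others in the source may bear on it.

Among the compounds with values here, compound 1 `COc1cccc(CNCCCNc2ccnc3cc(Oc4ccc(Cl)cc4)ccc23)c1O` is one of three compounds measured in a physicochemical assay for solubility, with a stated time of 18 h, at pH 7.4 (a lower number here means a less soluble compound, a higher number a more soluble compound), where compound 1 gives 14500 nM. Compound 3 `COc1ccc(F)cc1CNCCCNc1ccnc2cc(Oc3ccc(C(C)(C)C)cc3)ccc12` gives 14500 nM in this assay, level with compound 1 at the digits shown, and the two together sit at the top of the three numbers. Within the data shown here, compound 2 `COc1ccc(F)cc1CNCCCNc1ccnc2cc(Cc3ccc(F)cc3)ccc12` gives 4200 nM, which lies a step below both; the only single change measured is a 3.5-fold higher number from compound 2 to compound 3 (0.54 log units; beyond the scatter).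

Compound 4 `COc1ccc(-c2ccc3c(NCCCNCc4cccc(OC)c4O)ccnc3c2)cc1` differs from compound 1 by 4-methoxyphenyl in place of 4-chlorophenoxy on an aromatic carbon. Among the measured compounds shown here, no measured step changes exactly this group: the step from compound 2 to compound 3 alters a different group with a different link to the shared core, so it can only show that a swap of this kind at this position is capable of moving the number by a modest amount. With no closer guide, the change for compound 4 is expected to stay near the scatter, and the expected step is a 1.1-fold higher number from compound 1 to compound 4 (0.04 log units; within the scatter). Compound 4 is therefore estimated at 16000 nM, within a range from 5000 nM to 45000 nM.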

Compound 4, solubility: 32000 nM
Compound 4: the middle estimate sits 2.0-fold (0.30 log units) below what was measured, within the range that was stated.
By their numbers in this assay, from the lowest: compound 2; then compounds 1 and 3 (each within the scatter of the next); then compound 4.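

In this assay the swap gives a 2.2-fold higher number from compound 1 to compound 4 (0.34 log units; beyond the scatter), the only step shown that keeps the side chain of compound 1 in place. It shows that the number at this position can move beyond the scatter even when the group that leaves and the group that enters match in heavy-atom count, in their single carbon-only aromatic ring and in hydrogen-bond donors and acceptors. No measurement shown explains why the number moves.

The step combines two differences, the oxygen link to the shared core and the chlorine traded for a methoxy group, and it cannot separate them. Going by these compounds, a 4-chlorophenyl or 4-methoxyphenoxy group at this position would pull them apart, and how an amine or a carboxylic acid on the outer ring would read remains open.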